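This account rests on a few compounds, and the source may have more. Where it says the series, first, only, none or still open, it means among the compounds named here.

Series notes. Compound 1 `COc1ccc(-c2cnc(NC(=O)c3cccc([N+](=O)[O-])c3)n2C)cc1` passes by the change cyano in place of nitro on an aromatic carbon into compound 2 `COc1ccc(-c2cnc(NC(=O)c3cccc(C#N)c3)n2C)cc1`. In a toxicity assay on THP-1 cells (Homo sapiens) for inhibition (a higher number here means that more compound is tolerated, a lower number that less compound is tolerated), compound 1 reports only a limit, > 100000 nM. In this assay compound 2 likewise reports only a limit, > 100000 nM. The step that the two limits leave unreadable from compound 1 to compound 2 is therefore unreadable. Compound 3 `COc1ccc(-c2cnc(NC(=O)c3ccc([N+](=O)[O-])cc3)n2C)cc1` has the same atoms as compound 1 joined differently; the difference between the two cores is not broken down here. In this assay compound 3 also gives only a limit, > 100000 nM. Compound 4 `COc1ccc(-c2cnc(NC(=O)c3ccc(C#N)cc3)n2C)cc1` is not yet measured; it arises from compound 3 by cyano in place of nitro on an aromatic carbon, the same kind of change as before, here para to a large group rather than meta. Every measured value sits at the limit of > 100000 nM in this assay, at which 3 of the 3 values shown sit. The step of a number no higher from compound 3 to compound 4 (the limit leaves the size open) is expected to be small, most likely again a limit. Compound 4 is estimated at 100000 nM, between 50000 nM and 300000 nM.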

Compound 4, half-maximal cytotoxic concentration: > 100000 nM
Compound 4: a limit, no number; the forecaster's own chance of this, stated with the estimate: 85%; the middle value sits exactly at the limit.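

No step can be read from compound 2 or compound 3 to compound 4, as each gives only a limit. The compounds shown leave open whether any of them has a measurable half-maximal cytotoxic concentration in this assay: the limit of > 100000 nM in this assay, at which 4 of the 4 values shown sit.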